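The source may hold more compounds than are shown below. What is called first, only, known or untested is meant among the compounds shown, and "the series" means these compounds.

Measured so far:
- Compound 1 `CCCCn1nc(-c2ccccc2)c(-c2ccccc2)cc1=O`: in an assay on microsomes from liver for inhibition of sterol O-acyltransferase 1 (Rattus norvegicus) (on this read-out lower numbers stand for stronger inhibition and higher numbers for weaker inhibition), compound 1 gives 176000 nM.
- Compound 2 `O=C(O)CCCCCCn1nc(-c2ccccc2)c(-c2ccccc2)cc1=O`: in this assay compound 2 gives > 300000 nM, which is a limit of the assay and not a number, see (the limit of > 300000 nM in this assay, at which 1 of the 3 values shown sits).
- Compound 3 `CCCCCCCNc1cc(-c2ccccc2)c(-c2ccccc2)nn1`: in this assay compound 3 gives 55000 nM.

Compound 3 carries the lowest of the two numbers; the gap to compound 1, its nearest neighbour, lies beyond the usual scatter, and the remaining value is a limit only.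

Compound 4 `CCCCCCCOc1cc(-c2ccccc2)c(-c2ccccc2)nn1` differs from compound 3 by heptyloxy in place of heptylamino on an aromatic carbon. Among the measured compounds shown here, the only step measured, an at least 1.7-fold higher number from compound 1 to compound 2 (0.23 log units; that floor lies within the scatter), concerns an added carboxylic acid chain on a different part of the shared core and runs into the limit, so it says nothing about an amine-to-ether swap at this position. For the measured compounds named here, no measured step bears on the change from compound 3 to compound 4. With nothing to build on, the expectation is no step beyond the scatter: a 1.5-fold higher number from compound 3 to compound 4 (0.16 log units; within the scatter) is expected. For compound 4 the estimate in this assay is 80000 nM, with a range from 25000 nM to 300000 nM.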

Compound 4, half-maximal inhibitory concentration: 58000 nM
Compound 4: middle estimate off by 1.4-fold (0.14 log units), on the high side; the measured number falls inside the stated range.
By their numbers in this assay, from the lowest: compounds 3 and 4 (each within the scatter of the next); then compound 1. At a limit, above all of these: compound 2.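

Heptyloxy in place of heptylamino on an aromatic carbon next to the ring nitrogen gives, in this assay, a 1.1-fold higher number from compound 3 to compound 4 (0.02 log units; within the scatter). Heptylamino carries a hydrogen-bond donor and heptyloxy carries none, yet compound 3 and compound 4 do not separate on this read-out, so at this position the two linking atoms are interchangeable for these heptyl chains. Nothing measured here gives a reason for this outcome.

Open, going by these compounds, is whether the same holds for other links at this carbon, such as heptylthio, N-methylheptylamino or a heptyl group attached directly. Also open, on these data alone, is how much the chain itself counts here, which a shorter butoxy or a longer decyloxy on the same core would test.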